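The compounds below may be only part of what the source reports. "The series", "measured", "known", "first", "only" and "open" are said of these compounds alone.

Working notes on the series. Of the compounds shown here, two are measured so far: compound 1 `COC(=O)C1=C(C)N(C)C(=O)NC1c1ccoc1` and compound 2 `COC(=O)C1=C(C)N(C)C(=O)NC1c1cccs1`. In an assay on membranes from CHO cells for displacement of a labelled ligand from adenosine receptor A1 (Homo sapiens), read by scintillation counting, with a stated time of 60 min, tested at 1 uM (a lower number here means less inhibition, a higher number more inhibition at the concentration tested (going by the name of the read-out)), compound 1 gives 15%, and in this assay compound 2 gives 30%. Compound 2 thus holds the higher of the two numbers, and the step of a number 15 percentage points higher from compound 1 to compound 2 (beyond the scatter) sets it apart from compound 1 beyond the scatter.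

Compound 3 `COC(=O)C1=C(C)N(C)C(=O)NC1c1ccsc1` is not yet measured. It differs from compound 2 by thiophen-3-yl in place of thiophen-2-yl on a saturated ring carbon. Going by the values given here, only one measured step bears on this, a number 15 percentage points higher from compound 1 to compound 2 (beyond the scatter), and that step changed both the hetero atom of the five-membered ring and its point of attachment at once; it does not isolate the attachment point alone. Compound 1 carries a furan-3-yl group and sits lower, compound 2 a thiophen-2-yl group and sits higher, so the separate weight of the hetero atom and of the attachment is not known from the data.

Compound 3 is therefore estimated at 22%, with a range from 8% to 38%. The expected step of a number 8 percentage points lower from compound 2 to compound 3 (within the scatter) is a modest decrease, close to the scatter.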

Compound 3, a percentage reported as inhibition, at one concentration (the size of the read-out at that concentration, not a potency): 24%
Compound 3: the middle estimate sits 2 percentage points below what was measured; measured number inside the range.
By their numbers in this assay, from the lowest: compounds 1, 3 and 2 (each within the scatter of the next, the first and the last beyond it).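

Taken alone, the change of attachment, thiophen-3-yl in place of thiophen-2-yl on the saturated ring carbon, gives a number 6 percentage points lower from compound 2 to compound 3 (within the scatter) in this assay, so no difference between the two attachment points can be read at this position at the concentration tested. With the attachment held and only the hetero atom changed, thiophen-3-yl in place of furan-3-yl gives a number 9 percentage points higher from compound 1 to compound 3 (within the scatter), which is also no readable difference, and so the step between compound 1 and compound 2, the only one of the three beyond the scatter, cannot be assigned to either part of that double change. No independent data bear on this result.

On these data alone, how furan-2-yl would read against these three groups at the same saturated ring carbon remains open, as does the reading for a phenyl ring there. Also open, as far as these compounds go, is whether a carboxylic acid in place of the methoxycarbonyl group, or an ethyl group in place of the methyl group on the ring, would shift the inhibition; the three compounds share both of these groups and give readings at a single concentration, not potencies.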